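A few compounds are considered here, and "the series" means these few. Any claim that something is new, unique, unknown or untested is made for them only; others in the source may bear on it.

In a functional assay for inhibition, with Rattus norvegicus as the target (on this read-out higher numbers stand for weaker inhibition and lower numbers for stronger inhibition), compound 2 `CC(C)(C)/N=c1\c(O)c(O)\c1=N/Cc1cccc(F)c1` gives 2400 nM, the lower of the two numbers shown, though its nearest neighbour lies within the scatter: compound 1 `CC(C)(C)/N=c1\c(O)c(O)\c1=N/Cc1cccnc1` gives 2600 nM. Compound 3 `C/N=c1\c(O)c(O)\c1=N/Cc1ccc(C#N)cc1` reaches only a limit in this assay, > 30000 nM, the limit at the limit of > 30000 nM in this assay, at which 1 of the 3 values shown sits. Compound 4 `CC(C)(C)/N=c1\c(O)c(O)\c1=N/Cc1ccccc1` has not yet been measured and differs from compound 2 by hydrogen in place of fluoro on an aromatic carbon. Among the compounds with values here, no measured pair isolates this change. Within the data shown here, compound 1 and compound 2 carry different rings yet sit within the scatter of each other, and that is the only guide available. The expected step is a 1.3-fold higher number from compound 2 to compound 4 (0.10 log units; within the scatter), no larger than the scatter in either direction. Compound 4 is therefore estimated at 3000 nM, with a range from 1200 nM to 8000 nM.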

Compound 4, half-maximal inhibitory concentration: 3400 nM
The estimate for compound 4 lay 1.1-fold (0.05 log units) below the measured number; the range from low to high includes it.
By their numbers in this assay, from the lowest: compounds 2, 1 and 4 (each within the scatter of the next). At a limit, above all of these: compound 3.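

In this assay, within the data shown here, hydrogen in place of fluoro on this aromatic carbon gives a 1.4-fold higher number from compound 2 to compound 4 (0.15 log units; within the scatter), so this pair isolates the change for the first time and the two groups cannot be told apart here. Phenyl in place of pyridin-3-yl gives a 1.3-fold higher number from compound 1 to compound 4 (0.12 log units; within the scatter), so that exchange of rings cannot be told apart in this assay either. Nothing measured here gives a cause for these steps. Still open, from the compounds shown here alone, is whether a methoxy group, an amine or a carboxylic acid on this same aromatic carbon would give a step beyond the scatter.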